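This account rests on a few compounds, and the source may have more. Where it says the series, first, only, none or still open, it means among the compounds named here.

Compound 1 `COc1cc(O)cc(CCCCCCC/C=C\CCCCCCCc2cc(OC)cc(OC)c2)c1`: 9.8 ug/mL
Compound 2 `Oc1cc(O)cc(CCCCC/C=C\CCCCCCCc2cc(O)cc(O)c2)c1`: 9.8 ug/mL

In a functional assay on A2780 cells (Homo sapiens) for cytotoxicity (a lower number here means a stronger inhibitor, a higher number a weaker inhibitor), compound 2 gives 9.8 ug/mL, level with compound 1 at the digits reported. Compound 3 `Oc1cc(O)cc(CCCCCCC/C=C\CCCCCCCc2cc(O)cc(O)c2)c1` has not yet been measured. It carries 2-(3,5-dihydroxyphenyl)ethyl in place of 3,5-dihydroxyphenyl on a saturated chain carbon, five bonds along the chain from a double-bonded chain carbon. Among the measured compounds shown here, no measured pair differs in one place, so the data give no direct guide to this change. The expected 1.1-fold lower number from compound 2 to compound 3 (0.04 log units; within the scatter) stays within the scatter, with no clear direction. Compound 3 is estimated at 9 ug/mL, with an expected range of 4 ug/mL to 20 ug/mL.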

Compound 3, half-maximal inhibitory concentration: 10.2 ug/mL
Compound 3: middle estimate off by 1.1-fold (0.05 log units), on the low side; the measured number falls inside the stated range.
By their numbers in this assay, from the lowest: compounds 1, 2 and 3 (each within the scatter of the next).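

In this assay, putting 2-(3,5-dihydroxyphenyl)ethyl in place of 3,5-dihydroxyphenyl on a saturated chain carbon, five bonds along the chain from a double-bonded chain carbon, gives a 1.0-fold higher number from compound 2 to compound 3 (0.02 log units; within the scatter). This single-place comparison, the first in the set, shows that the read-out stays level across this change at this position. No measurement here offers an explanation for that.

On these data alone, whether a much longer chain at this position would also leave the read-out level remains open. So does the effect of an amine or a carboxylic acid in place of the 3,5-dihydroxyphenyl group.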